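Pyridin-2-yl on a compound already at the limit

The compounds below may be only part of what the source reports. "The series", "measured", "known", "first", "only" and "open" are said of these compounds alone.

In a functional assay on BXPC-3 cells (Homo sapiens) for antiproliferative activity, read by sulforhodamine B assay, with a stated time of 72 h (on this read-out lower numbers stand for stronger inhibition and higher numbers for weaker inhibition), compound 1 `CC(C)(C)c1[nH]cnc1/C=c1\[nH]c(=O)/c(=C/c2cccc(C(=O)c3ccccc3)c2)[nH]c1=O` gives 0.63 nM. Compound 2 `O=C(c1ccccc1)c1cccc(/C=c2\[nH]c(=O)/c(=C/c3ccccn3)[nH]c2=O)c1` gives 6.27 nM in this assay. Compound 3 `CC(C)(C)c1[nH]cnc1/C=c1\[nH]c(=O)/c(=C/c2cccc(C(=O)N3CCC3)c2)[nH]c1=O` is the only one of the three without a number. For compound 3, the reading of > 500 nM is a limit. Azetidin-1-yl in place of phenyl on a carbonyl carbon comes with an at least 790-fold higher number from compound 1 to compound 3 (2.89 log units; beyond the scatter), a large step.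

Compound 4 `O=C(c1cccc(/C=c2\[nH]c(=O)/c(=C/c3ccccn3)[nH]c2=O)c1)N1CCC1` keeps the azetidin-1-yl of compound 3 and differs from it in one place: pyridin-2-yl in place of 5-(tert-butyl)-1H-imidazol-4-yl on a double-bonded chain carbon bound to an aromatic carbon. This is pyridin-2-yl in place of 5-(tert-butyl)-1H-imidazol-4-yl on a double-bonded chain carbon bound to an aromatic carbon. The same exchange has been measured once, with phenyl on the carbonyl carbon, and it gave a 10-fold higher number from compound 1 to compound 2 (1.00 log units; beyond the scatter), a modest step towards weaker inhibition. Among the compounds with values here, no measured pair shows the exchange with azetidin-1-yl present, so this single step is the only guide. A modest step in the same direction is therefore expected in this assay, and the assay may well report only a limit again. The expected change is a step that the limit leaves unreadable from compound 3 to compound 4. For compound 4 the estimate is 2000 nM, with an expected range of 400 nM to 10000 nM.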

Compound 4, half-maximal inhibitory concentration: > 500 nM
Compound 4: only a limit was reported; the forecaster's own chance of this, stated with the estimate: 75%; the middle value is on the limit's open side.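

With pyridin-2-yl on the double-bonded chain carbon, azetidin-1-yl in place of phenyl on a carbonyl carbon again goes with much weaker inhibition, an at least 79-fold higher number from compound 2 to compound 4 (1.90 log units; beyond the scatter). Within the data shown here, the loss that the earlier compounds showed with 5-(tert-butyl)-1H-imidazol-4-yl on that chain carbon is therefore seen with pyridin-2-yl as well, although its full size stays open on both cores: the same change on two cores in this assay, an at least 790-fold higher number (2.89 log units; beyond the scatter) from compound 1 to compound 3 and an at least 79-fold higher number (1.90 log units; beyond the scatter) from compound 2 to compound 4; the limit leaves it open whether they differ. The step for pyridin-2-yl in place of 5-(tert-butyl)-1H-imidazol-4-yl with azetidin-1-yl present cannot be read, so the modest step seen with phenyl on the carbonyl carbon finds neither support nor contradiction here: the limit of > 500 nM in this assay, at which 2 of the 4 values shown sit.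

Among the compounds shown, the carbonyl carbon carries only phenyl or azetidin-1-yl, so it remains open whether a morpholin-4-yl, a methyl or a cyclohexyl group there would stay close to phenyl or fall to the limit in this assay. From the compounds shown here alone, it also remains open how far compound 3 and compound 4 lie past their limits, and whether the two groups on the chain carbon differ at all when azetidin-1-yl is present.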